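The source may hold more compounds than are shown below. What is called first, only, known or untested is meant among the compounds shown, and "the series" means these compounds.

Measured compounds:
Compound 1 `O=C(C1CC1)[C@H]1C[C@H]2CNC[C@H]2C1` — in an assay on CHO cells for displacement of a labelled ligand from Neuronal acetylcholine receptor; alpha3/beta4 (Homo sapiens), read by scintillation counting, with a stated time of 2 h (a higher number here means a weaker inhibitor, a lower number a stronger inhibitor), compound 1 gives 70 nM.
Compound 2 `O=C(c1ccco1)[C@H]1C[C@@H]2CNC[C@@H](C2)C1` — in this assay compound 2 gives "not determined" (no result reported); no result was reported.

The piece follows the step from compound 2 to compound 3 `CC(C)NC(=O)[C@H]1C[C@@H]2CNC[C@@H](C2)C1`. Compound 2 stands nowhere on the numbers shown: its measurement in this assay is missing, so it can serve only as the structural starting point. Compound 3 differs from compound 2 in one place, described as isopropylamino in place of furan-2-yl on a carbonyl carbon. The carbonyl carbon is kept, but the ring that sat on it is exchanged for a chain carrying an amide hydrogen.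

Within the data shown here, no step between measured compounds is available, and compound 2 itself lacks a number, so no direction or size can be read off for this change in this assay. Among the measured compounds shown here, the only anchor is compound 1, which shares a related saturated core with a ketone and reaches 70 nM. Compound 3 is estimated to lie in a weaker region than that anchor, at about 300 nM, with a likely range from 30 nM to 3000 nM.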

Compound 3, inhibition constant: 6000 nM
Estimate against measurement, compound 3: 20-fold (1.30 log units) below; measured number outside the range, above it.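

No step can be read between compound 2 and compound 3 in this assay, and compound 1 differs from compound 3 in more than one place. The compounds shown leave open how isopropylamino in place of furan-2-yl on the carbonyl carbon shifts the inhibition constant. No supporting data bear on this result.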